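The source may report more compounds than this note shows. Statements on the series, on what has been measured and on what is new or still open speak of the compounds shown alone.

Compound 1 `COc1cccc(OCCCCCN2CCCC(COC(=O)c3ccccc3N3C(=O)CC(C)C3=O)C2)c1OC` and compound 2 `O=C(OC1CCCN(CCCc2ccccc2)C1)c1ccccc1-c1ccccc1` were both tested in an in vitro functional assay on HEK ts201 cells for antagonist activity at Neuronal acetylcholine receptor; alpha4/beta2 (Homo sapiens), read by fluorescence and calcium flux; on this read-out lower numbers stand for stronger inhibition and higher numbers for weaker inhibition. In this assay compound 1 gives 8710 nM, the higher of the two numbers, while compound 2 gives 6500 nM; the gap between them lies within the scatter, so the two are not distinguished. Compound 3 `CC1CC(=O)N(c2ccccc2C(=O)OCC2CCCN(CCCCCOc3ccc(Cl)c(Cl)c3)C2)C1=O` is compound 1 with one change: 3,4-dichlorophenyl in place of 2,3-dimethoxyphenyl on an oxygen on a saturated carbon. Within the data shown here, no measured pair shows this change, so its size is unknown. A modest step, expected as a 1.7-fold lower number from compound 1 to compound 3 (0.24 log units; within the scatter), seems as likely as none beyond the scatter. For compound 3 the expected value is 5000 nM, with a range from 1500 nM to 15000 nM.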

Compound 3, half-maximal inhibitory concentration: 17400 nM
Beside the measured number, compound 3's estimate is 3.5-fold (0.54 log units) below it; measured number outside the range, above it.
By their numbers in this assay, from the lowest: compounds 2, 1 and 3 (each within the scatter of the next, the first and the last beyond it).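

Placing 3,4-dichlorophenyl where compound 1 carries 2,3-dimethoxyphenyl, on an oxygen on a saturated carbon, gives a 2.0-fold higher number from compound 1 to compound 3 (0.30 log units; within the scatter) in this assay on otherwise the same structure. This first measured example of the change therefore shows two quite different aromatic groups at this position that the assay cannot tell apart. No supporting data bear on this result. From the compounds shown here alone, whether an unsubstituted phenyl or a pyridyl group at this position would give a number beyond the scatter remains open, and so does the effect of a shorter chain.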